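A Methoxy Group Added to a Small Lactone

The compounds below may be only part of what the source reports. "The series", "measured", "known", "first", "only" and "open" are said of these compounds alone.

compound 1 `COc1ccc2cc(CCCOCCCc3cccnc3)oc(=O)c2c1` — 27 ug/mL
compound 2 `O=C1OC(CO)Cc2ccccc21` — >= 250 ug/mL

Of the compounds shown here, two have been tested in an ADME assay on HaCaT cells (Homo sapiens) for cytotoxicity, read by sulforhodamine B assay, with a stated time of 48 h (a lower number here means a stronger inhibitor of growth, a higher number a weaker inhibitor of growth), a measure of how strongly a compound slows the growth of skin cells. Compound 1 gives 27 ug/mL. Compound 2 reaches only a limit of the assay, >= 250 ug/mL, so no exact number is known for it. That is where compound 2 stands: at the limit of >= 250 ug/mL in this assay, at which 1 of the 2 values shown sits. Among the measured compounds shown here, the two values show compound 1 well inside the measured range and compound 2 at its edge; no single-point step connects them, as they differ in more than one place.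

Compound 3 `COc1ccc2c(c1)C(=O)OC(CO)C2` differs from compound 2 by methoxy in place of hydrogen on an aromatic carbon. For the measured compounds named here, with no measured step to lean on, the expected change is a number no higher from compound 2 to compound 3 (the limit leaves the size open), that is, nothing beyond the usual scatter, and compound 3 is expected to land near 250 ug/mL, plausibly anywhere from 100 ug/mL to 500 ug/mL, most likely again as a limit rather than a number.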

Compound 3, concentration for 50% growth inhibition: >= 250 ug/mL
Compound 3 was reported as a limit (the forecaster's own chance of this, stated with the estimate: 65%); the middle value sits exactly at the limit.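

Compound 2 and compound 3 both stop at a limit of the assay, not at a number, so no step can be read between them: the limit of >= 250 ug/mL in this assay, at which 2 of the 3 values shown sit.

The compounds shown leave open whether methoxy in place of hydrogen on an aromatic carbon changes growth inhibition at all in this assay.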